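The compounds below may be only part of what the source reports. "The series", "measured", "known", "first", "only" and "open" are said of these compounds alone.

Measured so far:
Compound 1, `Cc1c[se]c(N/N=C/c2ccc(Cl)cc2)n1`: 49400 nM
Compound 2, `COc1ccc(/C=N/Nc2nc(C)c[se]2)cc1`: a limit of the assay, > 84900 nM
Compound 3, `CC(=O)N(/N=C/c1ccc(Cl)cc1)c1nc(C)c[se]1`: 60600 nM

In a functional assay on DU-145 cells (Homo sapiens) for cytotoxicity, read by XTT assay, with a stated time of 72 h (on this read-out higher numbers stand for weaker inhibition and lower numbers for stronger inhibition), compound 1 gives 49400 nM. Compound 2 reaches only a limit of the assay, > 84900 nM. Compound 3 gives 60600 nM. From compound 1 to compound 2 the change is methoxy in place of chloro on an aromatic carbon, and the step was an at least 1.7-fold higher number from compound 1 to compound 2 (0.23 log units; that floor lies within the scatter). Compound 3 carries a changed core: acetyl in place of hydrogen on a nitrogen on an aromatic ring, with a 1.2-fold higher number from compound 1 to compound 3 (0.09 log units; within the scatter). Compound 4, `COc1ccc(/C=N/N(C(C)=O)c2nc(C)c[se]2)cc1`, is not yet measured. It differs from compound 3 by the same kind of change, (methoxy in place of chloro on an aromatic carbon); here the place is described as para to a large group, whereas for the first pair it is para to a group of 9 heavy atoms. Resting on the earlier step of an at least 1.7-fold higher number from compound 1 to compound 2 (0.23 log units; that floor lies within the scatter) and on the value of compound 3, 60600 nM, compound 4 is expected to show a 1.7-fold higher number from compound 3 to compound 4 (0.22 log units; within the scatter). Compound 4 is therefore estimated at 100000 nM, likely between 50000 nM and 250000 nM, and in this assay it may well come back only as a limit.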

Compound 4, half-maximal inhibitory concentration: > 74300 nM
Compound 4: no number, only a limit; the forecaster's own chance of this, stated with the estimate: 55%; the middle value is on the limit's open side.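

In this assay compound 4 gives only a limit of the assay (> 74300 nM). Methoxy in place of chloro on the core of compound 3 therefore gives an at least 1.2-fold higher number from compound 3 to compound 4 (0.08 log units; that floor lies within the scatter) and, with limits on both compounds that carry methoxy, the steps between those two cannot be read. The change shows no sign of acting differently on the two cores, but this does not show that it carries over unchanged, for the true size of each step stays hidden and neither floor rises beyond the usual scatter: the same change on two cores in this assay, an at least 1.7-fold higher number (0.23 log units; that floor lies within the scatter) from compound 1 to compound 2 and an at least 1.2-fold higher number (0.08 log units; that floor lies within the scatter) from compound 3 to compound 4; the limit leaves it open whether they differ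

The compounds shown have only chloro or methoxy at this place on the aromatic ring, so how an amine or a carboxylic acid there would read in this assay stays open. Also open, going by these compounds, is what a longer chain in place of the acetyl would do, and whether any such change would give a number clearly apart from those seen so far.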